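This account rests on a few compounds, and the source may have more. Where it says the series, first, only, none or still open, it means among the compounds named here.

Compound 1 `O=C(CSc1nnnn1-c1cccc2ccccc12)N/N=C/c1ccc(Cl)cc1`: > 295000 nM. Compound 2 `O=C(CSc1nnnn1-c1cccc2ccccc12)N/N=C/c1cccc(Cl)c1`: 240000 nM. Compound 3 `O=C(CSc1nnnn1-c1cccc2ccccc12)N/N=C/c1ccccc1F`: >= 118000 nM.

In an ADME assay on MT4 cells (Homo sapiens) for cytotoxicity, read by MTT assay (a lower number here means that less compound is tolerated, a higher number that more compound is tolerated), compound 1 gives no number, only a limit of the assay, > 295000 nM; this is the limit of > 295000 nM in this assay, at which 1 of the 3 values shown sits. Compound 3 likewise gives only a limit, >= 118000 nM. Compound 2 gives a number, 240000 nM. Compound 4 `O=C(CSc1nnnn1-c1cccc2ccccc12)N/N=C/c1cccc(O)c1` differs from compound 1 in one place: 3-hydroxyphenyl in place of 4-chlorophenyl on a carbon with a double bond to nitrogen. The step that bears most on it is an at least 1.2-fold lower number from compound 1 to compound 2 (0.08 log units; that floor lies within the scatter), while a step that the two limits leave unreadable from compound 1 to compound 3 and a step that the limit leaves unreadable from compound 2 to compound 3 give no readable size. No step beyond the scatter is therefore expected in this assay. For compound 4 the expected value is 250000 nM, between 110000 nM and 400000 nM. That estimate means an expected step of an at least 1.1-fold lower number from compound 1 to compound 4 (0.07 log units; that floor lies within the scatter).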

Compound 4, half-maximal cytotoxic concentration: 169000 nM
Beside the measured number, compound 4's estimate is 1.5-fold (0.17 log units) above it; measured number inside the range.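

In this assay, hydroxy in place of chloro on an aromatic carbon gives a 1.4-fold lower number from compound 2 to compound 4 (0.15 log units; within the scatter) and so brings no readable change, even though 3-hydroxyphenyl adds a hydrogen-bond donor and a hydrogen-bond acceptor that 3-chlorophenyl lacks. Compound 1 has only a limit, so the comparison with it gives just an at least 1.7-fold lower number from compound 1 to compound 4 (0.24 log units; that floor lies within the scatter) and that floor shows no change beyond the scatter. The step from compound 3 to compound 4 cannot be read: the limit of >= 118000 nM in this assay, at which 1 of the 4 values shown sits.

Going by these compounds, whether an amine or a carboxylic acid on this aromatic ring would shift the number beyond the scatter remains open.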